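This account rests on a few compounds, and the source may have more. Where it says the series, first, only, none or still open, it means among the compounds named here.

Measured compounds:
compound 1 `O=C(Nc1cccc(-n2cc(-c3ccncc3)c(-c3cc(O)cc(Cl)c3)n2)c1)Nc1ccc(Cl)c(Cl)c1`: 105%
compound 2 `COc1cc(Cl)cc(-c2nn(-c3cccc(NC(=O)Nc4ccc(Cl)c(C(F)(F)F)c4)c3)cc2-c2ccncc2)c1`: 100%

In a functional assay on HOP-62 cells (Homo sapiens) for inhibition, read by sulforhodamine B assay, with a stated time of 48 h, tested at 0.01 uM (on this read-out higher numbers stand for a weaker effect at the one concentration tested and lower numbers for a stronger effect), compound 2 stands at the smaller of the two numbers shown, yet compound 1 lies within the usual scatter of it, so the two cannot be told apart. Compound 3 `COc1cc(Cl)cc(-c2nn(-c3cccc(NC(=O)Nc4cccc(C(F)(F)F)c4)c3)cc2-c2ccncc2)c1` differs from compound 2 by hydrogen in place of chloro on an aromatic carbon. Among the measured compounds shown here, no step between measured compounds is available to gauge this change; a step from compound 2 to compound 3 of a number 1 percentage points higher from compound 2 to compound 3 (within the scatter) is expected, that is none beyond the scatter. Compound 3 is therefore estimated to give 101% in this assay, with a range from 88% to 114%.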

Compound 3, a percentage reported as activity, at one concentration (the size of the read-out at that concentration, not a potency): 96%
For compound 3 the middle estimate is 5 percentage points above the measured one; measured number inside the range.
By their numbers in this assay, from the lowest: compounds 3, 2 and 1 (each within the scatter of the next).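

Hydrogen in place of chloro on this aromatic carbon, ortho to a trifluoromethyl group and para to a large group, gives a number 4 percentage points lower from compound 2 to compound 3 (within the scatter) in this assay. Among the compounds shown here, this is the first step that isolates a single change, and at this one concentration the read-out does not separate the 4-chloro-3-(trifluoromethyl)phenyl group from the 3-(trifluoromethyl)phenyl group. No independent measurement offers an explanation for this result.

The compounds shown leave open whether an amine or a carboxylic acid on this carbon would give a step beyond the scatter.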